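A few compounds are considered here, and "the series" means these few. Any claim that something is new, unique, unknown or untested is made for them only; others in the source may bear on it.

Measured in a functional assay on HeLa cells (Homo sapiens) for antiproliferative activity, read by CCK-8 assay, with a stated time of 72 h (a higher number here means a weaker inhibitor of growth, a lower number a stronger inhibitor of growth), so far:
- compound 1 `CCNC(=O)c1ccc2c(ccn2-c2ncc3c(n2)N(c2ccn(C)n2)C(CC)C(=O)N3C)c1` at 11100 nM
- compound 2 `CCC1C(=O)N(C)c2cnc(-n3ccc4cc(C(=O)NCC(C)C)ccc43)nc2N1c1ccn(C)n1` at 4970 nM

Compound 2 at 4970 nM holds the lower of the two numbers, with its gap to compound 1 beyond the scatter. Next comes compound 3 `CCC1C(=O)N(C)c2cnc(-n3ccc4cc(C(=O)NC5CCCC5)ccc43)nc2N1c1ccn(C)n1` with the change cyclopentyl in place of isobutyl on an amide-type nitrogen in which cyclopentyl takes the place of isobutyl on an amide-type nitrogen. Among the measured compounds shown here, one measured step bears on this: a 2.2-fold lower number from compound 1 to compound 2 (0.35 log units; beyond the scatter), a modest one, also in the group carried by that nitrogen. For the measured compounds named here, no measured compound has a ring in that group, so the guide is weak. A small further fall in this assay is expected, possibly not beyond the scatter. The expected step is a 1.4-fold lower number from compound 2 to compound 3 (0.15 log units; within the scatter) as estimated here. For compound 3 the estimate is 3500 nM with an expected range from 1400 nM to 9000 nM in this read-out.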

Compound 3, concentration for 50% growth inhibition: 27400 nM
For compound 3 the middle estimate is 7.8-fold (0.89 log units) below the measured one; the measured number lies above the stated range.
By their numbers in this assay, from the lowest: compound 2; then compound 1; then compound 3.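

In this assay, the group on the amide-type nitrogen proves sensitive to the change from isobutyl to cyclopentyl, which adds one carbon and a ring and gives a 5.5-fold higher number from compound 2 to compound 3 (0.74 log units; beyond the scatter), the first ring at this position and the first step upward in the series. Cyclopentyl also compares poorly with ethyl, with a 2.5-fold higher number from compound 1 to compound 3 (0.39 log units; beyond the scatter), so the number does not simply fall as the carbon group on this nitrogen grows, and compound 3 goes against the fall seen from compound 1 to compound 2. No supporting measurement speaks to the origin of this rise.

Open, going by these compounds, is whether the rise follows the ring as such or this particular group: a cyclopropyl or cyclohexyl ring, or a longer open chain, on the same nitrogen would help separate these. Also open, on these data alone, is how a ring or chain bearing an amine or a hydroxyl would read here.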